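This account rests on a few compounds, and the source may have more. Where it says the series, first, only, none or still open, it means among the compounds named here.

Measured compounds:
Compound 1, `CN(C(=O)C(C)(C)C)c1ccc2[nH]c(-c3n[nH]c4ccccc34)cc2n1`, in a functional assay on HCT-116 cells (Homo sapiens) for antiproliferative activity, read by MTT assay, with a stated time of 72 h (on this read-out higher numbers stand for weaker inhibition and lower numbers for stronger inhibition), gives 18000 nM.
Compound 2, `COc1cccc(C(=O)N(C)c2ccc3[nH]c(-c4n[nH]c5ccccc45)cc3n2)c1`, in this assay gives 14200 nM.

Within the data shown here, compound 2 holds the lowest of the two numbers so far, but its nearest neighbour is compound 1, and the step of a 1.3-fold lower number from compound 1 to compound 2 (0.10 log units; within the scatter) lies within the scatter, so the two cannot be ranked against each other. Compound 3, `CN(C(=O)c1ccco1)c1ccc2[nH]c(-c3n[nH]c4ccccc34)cc2n1`, is the next compound to be measured in this assay. It differs from compound 2 in one place: furan-2-yl in place of 3-methoxyphenyl on a carbonyl carbon. Among the measured compounds shown here, the only measured step that bears on this position is a 1.3-fold lower number from compound 1 to compound 2 (0.10 log units; within the scatter), which exchanged one group for another on the same carbonyl carbon and stayed within the scatter. On that basis the expected step of a 1.1-fold higher number from compound 2 to compound 3 (0.02 log units; within the scatter) is none beyond the scatter. Compound 3 is therefore estimated to give 15000 nM in this assay, with a range from 7000 nM to 32000 nM.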

Compound 3, half-maximal inhibitory concentration: 30000 nM
Compound 3: middle estimate off by 2.0-fold (0.30 log units), on the low side, within the range that was stated.
By their numbers in this assay, from the lowest: compounds 2, 1 and 3 (each within the scatter of the next, the first and the last beyond it).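

Among these compounds, the first exchange on this carbonyl carbon stayed within the scatter, but in this assay this position now yields a modest step beyond it: a 2.1-fold higher number from compound 2 to compound 3 (0.32 log units; beyond the scatter), with furan-2-yl in place of 3-methoxyphenyl. The same furan-2-yl group in place of tert-butyl gives a 1.7-fold higher number from compound 1 to compound 3 (0.22 log units; within the scatter), which is within the scatter, so the change of group matters only for the pair with 3-methoxyphenyl and the three groups form no clear order. Nothing measured here accounts for the step.

From the compounds shown here alone, it remains open whether an amine, a carboxylic acid or a longer chain on this carbonyl carbon would move the number further in either direction. The contribution of the methoxy group within 3-methoxyphenyl also remains unresolved, and plain phenyl on this carbonyl carbon would provide that comparison.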